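A few compounds are considered here, and "the series" means these few. Any claim that something is new, unique, unknown or untested is made for them only; others in the source may bear on it.

Compound 1 `COc1ccc(NC(=O)CN2CCN(c3nnc(Cc4ccncc4)c4ccccc34)CC2)cc1OC`: 40100 nM
Compound 2 `Cc1ccc(F)cc1NC(=O)CN1CCN(c2nnc(Cc3ccncc3)c3ccccc23)CC1`: 470 nM
Compound 3 `Cc1ccccc1NC(=O)CN1CCN(c2nnc(Cc3ccncc3)c3ccccc23)CC1`: 15000 nM

In a functional assay on HT-29 cells (Homo sapiens) for cytotoxicity, read by MTT assay, with a stated time of 72 h (on this read-out lower numbers stand for stronger inhibition and higher numbers for weaker inhibition), compound 3 gives 15000 nM, the second highest of the three numbers. Compound 4 `Cc1cccc(Cl)c1NC(=O)CN1CCN(c2nnc(Cc3ccncc3)c3ccccc23)CC1` has chloro in place of hydrogen on an aromatic carbon of compound 3: chloro in place of hydrogen on an aromatic carbon. Among the compounds with values here, only one measured step concerns a halogen on this ring, the large step of a 32-fold higher number from compound 2 to compound 3 (1.50 log units; beyond the scatter). Read backwards, it links fluoro with a lower number. Chloro is a different group at a different place, so that step is only a loose guide, and a smaller drop is expected. The estimated step is a 5.0-fold lower number from compound 3 to compound 4 (0.70 log units; beyond the scatter). For compound 4 the expected value is 3000 nM, within an estimated range from 300 nM to 20000 nM.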

Compound 4, half-maximal inhibitory concentration: 22600 nM
Compound 4: the middle estimate sits 7.5-fold (0.88 log units) below what was measured; the measured number lies above the stated range.
By their numbers in this assay, from the lowest: compound 2; then compounds 3, 4 and 1 (each within the scatter of the next, the first and the last beyond it).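

In this assay, chloro at this place on the 2-methylphenyl ring leaves the number within the scatter (a 1.5-fold higher number from compound 3 to compound 4 (0.18 log units; within the scatter)), so a halogen on this ring does not always bring the large drop seen with compound 2. The 2-chloro-6-methylphenyl group stays well short of the 5-fluoro-2-methylphenyl group (a 48-fold higher number from compound 2 to compound 4 (1.68 log units; beyond the scatter)) and cannot be told apart from the 3,4-dimethoxyphenyl group (a 1.8-fold lower number from compound 1 to compound 4 (0.25 log units; within the scatter)). Nothing measured here gives a reason for this gap between the two halogen-bearing rings. Open, going by these compounds, is whether fluoro at the chloro position would behave like chloro, and whether an amine or a carboxylic acid on this ring would shift the number.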